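Fluoro for chloro at a cytotoxicity limit

This account rests on a few compounds, and the source may have more. Where it says the series, first, only, none or still open, it means among the compounds named here.

In an ADME assay on MT4 cells (Homo sapiens) for cytotoxicity, read by MTT assay (on this read-out lower numbers stand for higher toxicity in this test and higher numbers for lower toxicity in this test), compound 3 (`COc1ccc(C(=O)CSc2nc(Cc3c(F)cccc3Cl)c(C(C)C)c(=O)[nH]2)cc1`) gives > 11000 nM as a limit and not a number. Compound 1 (`COc1ccc(C(=O)CSc2nc(Cc3c(F)cccc3Cl)c(C)c(=O)[nH]2)cc1`) gives > 12000 nM as a limit too. Compound 2 (`CC(C)c1c(Cc2c(F)cccc2Cl)nc(SCC(=O)c2ccc(F)cc2)[nH]c1=O`) gives > 56000 nM as a limit as well. All three compounds therefore lack an exact reading, and they cannot be ranked against one another.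

The next compound, compound 4 (`COc1ccc(C(=O)CSc2nc(Cc3c(F)cccc3F)c(C(C)C)c(=O)[nH]2)cc1`), keeps the shared core of compound 3 and makes one change. That change is fluoro in place of chloro on an aromatic carbon and puts fluoro in place of chloro on an aromatic carbon, turning 2-chloro-6-fluorobenzyl into 2,6-difluorobenzyl.

Two measured steps lie closest to it, yet neither touches that group. One is a step that the two limits leave unreadable from compound 1 to compound 3 and swaps methyl for isopropyl. The other is a step that the two limits leave unreadable from compound 2 to compound 3 and swaps fluoro for methoxy. Neither gives a size to carry over, so no step beyond the usual scatter is expected, in either direction. The estimated step is a step that the limit leaves unreadable from compound 3 to compound 4 and rests on that expectation alone. The estimate for compound 4 is 20000 nM with an expected range from 9000 nM to 60000 nM and may well arrive as a limit only.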

Compound 4, half-maximal cytotoxic concentration: 33000 nM
Compound 4: middle estimate off by 1.7-fold (0.22 log units), on the low side; measured number inside the range.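

In this assay compound 3 gives > 11000 nM, which is a limit and not a number. The step from compound 3 to compound 4 cannot be read, even though compound 4 has an exact value. The compounds shown leave open whether turning 2-chloro-6-fluorobenzyl into 2,6-difluorobenzyl changes the cytotoxicity reading at all, and in which direction.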